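The source may hold more compounds than are shown below. What is called first, only, known or untested is meant among the compounds shown, and "the series" means these compounds.

Measured compounds:
Compound 1, `O=C(NC/C=C\Cn1cc(F)c(=O)[nH]c1=O)c1ccccc1`: in a functional assay on MIA PaCa-2 cells (Homo sapiens) for cytotoxicity, read by MTT assay, with a stated time of 72 h (on this read-out higher numbers stand for weaker inhibition and lower numbers for stronger inhibition), compound 1 gives a limit of > 100000 nM.
Compound 2, `Nc1ccn(C/C=C\CNC(=O)c2ccccc2)c(=O)n1`: in this assay compound 2 gives a limit of > 100000 nM.

Neither of these is a number; each is a limit of the assay. For the measured compounds named here, compound 2 therefore stands exactly where the one other value stands, namely at the limit of > 100000 nM in this assay, at which 2 of the 2 values shown sit. Going by the values given here, no step between measured compounds can be drawn from this, and the two values show only that both compounds sit at the limit.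

Compound 3, `Nc1ccn(C/C=C\CNC(=O)c2ccc(F)cc2)c(=O)n1`, differs from compound 2 by fluoro in place of hydrogen on an aromatic carbon, in words fluoro in place of hydrogen on an aromatic carbon, para to a large group; cut one bond further out, the change reads phenyl to 4-fluorophenyl.

Among the compounds with values here, with both measured values at the limit and no step of known size to lean on, the step of a number no higher from compound 2 to compound 3 (the limit leaves the size open) is expected to be none beyond the scatter. Compound 3 is accordingly expected to give about 100000 nM, with a range from 30000 nM to 300000 nM, most likely reported again as a limit.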

Compound 3, half-maximal inhibitory concentration: > 100000 nM
Compound 3: a limit, no number; the forecaster's own chance of this, stated with the estimate: 85%; the middle value lies on the limit itself.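

In this assay compound 3 gives > 100000 nM, which is a limit and not a number. For the compounds shown here, compound 2 also stands at a limit, and no step from it to compound 3 can be read. The compounds shown leave open how they rank against one another, as all of them share one limit: the limit of > 100000 nM in this assay, at which 3 of the 3 values shown sit.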